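A few compounds are considered here, and "the series" means these few. Any claim that something is new, unique, unknown or untested is made for them only; others in the source may bear on it.

Measured compounds:
- compound 1, `CCC(Nc1ccc(S(=O)(=O)Nc2nccs2)cc1Cl)c1ccccc1`, 50 nM in an assay on HEK293 cells for inhibition of SCN8A/SCN1B (Homo sapiens), read by patch clamp, with a stated time of 20 min; on this read-out higher numbers stand for weaker inhibition and lower numbers for stronger inhibition
- compound 2, `CC(Nc1ccc(S(=O)(=O)Nc2nccs2)cc1Cl)c1ccccc1`, 100 nM in this assay
- compound 3, `C[C@H](Nc1cc(F)c(S(=O)(=O)Nc2cscn2)cc1Cl)c1cc(CN2CCC2)ccc1F`, 120 nM in this assay

Compound 1 and compound 2 share one core; the change between them is hydrogen in place of methyl on a saturated chain carbon, two bonds along the chain from an aromatic carbon and a nitrogen on an aromatic ring, and it made a step of a 2.0-fold higher number from compound 1 to compound 2 (0.30 log units; within the scatter). Compound 3 is built on a different core; the difference between the two cores is not broken down here. The values of compound 3 and compound 2 lie within the scatter of each other, while compound 3 stands further from compound 1.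

Compound 4, `O=S(=O)(Nc1cscn1)c1cc(Cl)c(NCc2cc(CN3CCC3)ccc2F)cc1F`, has not yet been measured. It arises from compound 3 by hydrogen in place of methyl on a saturated chain carbon bound to an aromatic carbon and a nitrogen on an aromatic ring. Going by the values given here, this is the same kind of change as the one from compound 1 to compound 2, not the same: there the methyl sat two bonds along the chain from an aromatic carbon and a nitrogen on an aromatic ring, here it sits on a saturated chain carbon bound to those atoms. Because the earlier change gave a 2.0-fold higher number from compound 1 to compound 2 (0.30 log units; within the scatter), a similar step is expected here, a 2.0-fold higher number from compound 3 to compound 4 (0.30 log units; within the scatter). For compound 4 the expected value in this assay is 240 nM, likely between 100 nM and 600 nM.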

Compound 4, half-maximal inhibitory concentration: 460 nM
Beside the measured number, compound 4's estimate is 1.9-fold (0.28 log units) below it; measured number inside the range.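

In this assay, putting hydrogen in place of methyl on the saturated chain carbon bound to an aromatic carbon and a nitrogen on an aromatic ring gave a 3.8-fold higher number from compound 3 to compound 4 (0.58 log units; beyond the scatter), a modest weakening of inhibition that lies beyond the usual scatter. Going by these compounds alone, the earlier step on the other core can be set beside it, and the two cannot be told apart: the same change on two cores in this assay, a 2.0-fold higher number (0.30 log units; within the scatter) from compound 1 to compound 2 and a 3.8-fold higher number (0.58 log units; beyond the scatter) from compound 3 to compound 4, 1.9-fold (0.28 log units) apart, within the scatter of two such steps This shows that removing a methyl group moved the number the same way on both cores and by amounts that agree within the scatter, but with only two pairs, one of them within the scatter on its own, it does not show that the step would hold on a further core or explain why it occurs.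

From the compounds shown here alone, how a longer chain such as propyl, or a hydroxymethyl group, would behave on that saturated chain carbon remains open on either core. Going by these compounds, whether the step holds in any other kind of measurement also remains open.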